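This account rests on a few compounds, and the source may have more. Where it says the series, first, only, none or still open, it means among the compounds named here.

Among the measured compounds shown here, in a functional assay on HeLa cells (Homo sapiens) for inhibition, read by MTT assay, with a stated time of 72 h (a higher number here means a weaker inhibitor, a lower number a stronger inhibitor), compound 3 `Nc1nc2cc(-c3nn(CCCCC(=O)NO)c4ncnc(N)c34)ccc2o1` gives 32200 nM as the only number in this set. Compound 1 `Nc1nc2cc(-c3nn(CCCCCCCCCC(=O)NO)c4ncnc(N)c34)ccc2o1` gives > 50000 nM here, which is a limit. Compound 2 `Nc1nc2cc(-c3nn(CCC(=O)NO)c4ncnc(N)c34)ccc2o1` gives > 150000 nM here, also a limit. Compound 4 `Nc1nc2cc(-c3nn(CCCCCCCCC(=O)NO)c4ncnc(N)c34)ccc2o1` differs from compound 3 by 4-(hydroxycarbamoyl)butyl in place of hydroxycarbamoyl on a saturated chain carbon, four bonds along the chain from an aromatic nitrogen and so carries 4-(hydroxycarbamoyl)butyl in place of hydroxycarbamoyl, four bonds along the chain from an aromatic nitrogen. The nearest measured step is an at least 1.5-fold lower number from compound 1 to compound 3 (0.19 log units; that floor lies within the scatter) and it acts at that same place. Also bearing on the change is an at least 4.6-fold lower number from compound 2 to compound 3 (0.66 log units; beyond the scatter) at two bonds along the chain. The estimate is a 1.2-fold higher number from compound 3 to compound 4 (0.09 log units; within the scatter) and so nothing beyond the scatter is expected, with a higher number the likelier side. Compound 4 is estimated at 40000 nM with a range from 15000 nM to 100000 nM expected.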

Compound 4, half-maximal inhibitory concentration: 10200 nM
The estimate for compound 4 lay 3.9-fold (0.59 log units) above the measured number; the measured number lies below the stated range.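

In this assay, lengthening the chain at this place gives the first readable gain in the series: a 3.2-fold lower number from compound 3 to compound 4 (0.50 log units; beyond the scatter). Measured against the shortest chain, the change is larger: an at least 14-fold lower number from compound 2 to compound 4 (1.16 log units; beyond the scatter). The number does not simply fall as the chain grows, and compound 1 goes against that trend: an at least 4.9-fold lower number from compound 1 to compound 4 (0.69 log units; beyond the scatter).

Compounds 1 and 2 stand at limits, so these two steps give only minimum sizes. As far as these compounds go, whether a carboxylic acid or an amine in place of the hydroxycarbamoyl end would keep the lower number of compound 4 remains open.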